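The source may hold more compounds than are shown below. What is called first, only, known or untested is meant among the compounds shown, and "the series" means these compounds.

Of the compounds shown here, three that share one core have so far been measured in a functional assay on CCRF-CEM cells (Homo sapiens) for inhibition, read by MTT assay, with a stated time of 72 h; on this read-out lower numbers stand for stronger inhibition and higher numbers for weaker inhibition. Compound 1, `COc1cc(NC(C)CCCNC(=O)Nc2cccc(F)c2)c2ncccc2c1`, gives 21000 nM. Compound 2, `COc1cc(NC(C)CCCNC(=O)Nc2ccc(Br)cc2)c2ncccc2c1`, gives 23000 nM in this assay. Compound 3, `COc1cc(NC(C)CCCNC(=O)Nc2cccc(O)c2)c2ncccc2c1`, gives 32000 nM in this assay. Compound 2 stands second highest of the three numbers; its nearest neighbour is compound 1, a step of a 1.1-fold higher number from compound 1 to compound 2 (0.04 log units; within the scatter), and its furthest is compound 3, a step of a 1.4-fold higher number from compound 2 to compound 3 (0.14 log units; within the scatter), so all three sit within the scatter of one another.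

The next compound, compound 4, `COc1cc(NC(C)CCCNC(=O)Nc2ccc(O)cc2)c2ncccc2c1`, differs from compound 2 in one place: hydroxy in place of bromo on an aromatic carbon. For the measured compounds named here, two measured steps bear on this change. The replacement of 4-bromophenyl by 3-hydroxyphenyl gave a 1.4-fold higher number from compound 2 to compound 3 (0.14 log units; within the scatter), and the replacement of fluoro by hydroxy on an aromatic carbon gave a 1.5-fold higher number from compound 1 to compound 3 (0.18 log units; within the scatter). Neither rises above the scatter, and nothing among the three compounds points to a larger effect for a hydroxy group on this ring. Compound 4 is therefore expected to show no step beyond the scatter in this assay, the estimated step from compound 2 being a 1.2-fold higher number from compound 2 to compound 4 (0.07 log units; within the scatter). On this basis compound 4 is estimated at 27000 nM in this assay, with a range from 13000 nM to 55000 nM.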

Compound 4, half-maximal inhibitory concentration: 23000 nM
Beside the measured number, compound 4's estimate is 1.2-fold (0.07 log units) above it; the range from low to high includes it.
By their numbers in this assay, from the lowest: compounds 1, 2, 4 and 3 (each within the scatter of the next).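

In this assay, the exchange of bromo for hydroxy at the ring position para to a large group is now tested directly, and it leaves the number in place (no change at the digits printed from compound 2 to compound 4 (within the scatter)), even though a hydrogen-bond donor and acceptor enter where the bromo group had neither. The earlier compounds shown here had offered only a 3-hydroxyphenyl comparison, whereas compound 4 allows the two hydroxyphenyl placements to be set side by side (a 1.4-fold lower number from compound 3 to compound 4 (0.14 log units; within the scatter)), and the step from the 3-fluorophenyl compound also stays small (a 1.1-fold higher number from compound 1 to compound 4 (0.04 log units; within the scatter)). At this position, then, bromo and hydroxy cannot be told apart in this read-out, and nothing available bears on the reason for this result.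

All four compounds lie within the scatter of one another, so the shown set does not reveal any change on this ring that moves the number beyond it. From the compounds shown here alone, it remains open whether an amine or a carboxylic acid on this ring, or a longer chain on the shared core, would do so.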